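The compounds below may be only part of what the source reports. "The series", "measured", "known", "first", "only" and "open" are said of these compounds alone.

In a functional assay on MOLT-4 cells (Homo sapiens) for antiproliferative activity, with a stated time of 48 h (on this read-out lower numbers stand for stronger inhibition and higher numbers for weaker inhibition), compound 1 `Nc1ccc(/C=C/C(=O)c2ccc(I)cc2)cc1` gives 7500 nM and compound 2 `COc1ccc(C(=O)/C=C/c2ccc(N)cc2)cc1` gives 19000 nM as the higher of the two numbers. Compound 3 `CCOc1ccc(C(=O)/C=C/c2ccc(N)cc2)cc1` differs from compound 2 by methyl in place of hydrogen on a saturated chain carbon bound to an oxygen on an aromatic ring in the change from methoxy to ethoxy. Going by the values given here, the one measured step that bears on this is a 2.5-fold higher number from compound 1 to compound 2 (0.40 log units; beyond the scatter) for methoxy in place of iodo on an aromatic carbon. Methyl in place of hydrogen is a smaller edit of that same methoxy, so a step no larger is expected, probably none beyond the scatter. The expected step is a 1.2-fold lower number from compound 2 to compound 3 (0.07 log units; within the scatter) on this reasoning. The estimate for compound 3 is 16000 nM within a range of 8000 nM to 32000 nM as expected from these numbers.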

Compound 3, half-maximal inhibitory concentration: 11000 nM
Beside the measured number, compound 3's estimate is 1.5-fold (0.16 log units) above it; measured number inside the range.
By their numbers in this assay, from the lowest: compounds 1, 3 and 2 (each within the scatter of the next, the first and the last beyond it).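

In this assay the change from methoxy to ethoxy, methyl in place of hydrogen on a saturated chain carbon bound to an oxygen on an aromatic ring, gives a 1.7-fold lower number from compound 2 to compound 3 (0.24 log units; within the scatter) and so leaves this edit unresolved from no change. Ethoxy in place of iodo gives a 1.5-fold higher number from compound 1 to compound 3 (0.17 log units; within the scatter) and so, unlike methoxy, ethoxy cannot be told apart from iodo at this place. Nothing at hand accounts for either step. Going by these compounds, whether a longer chain such as propoxy, or a hydroxyl group, would move the number beyond the scatter stays open.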